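Methyl to isopropyl on compound 3

This account rests on a few compounds, and the source may have more. Where it says the series, first, only, none or still open, it means among the compounds named here.

In a functional assay (mast cells) for inhibition, with Rattus norvegicus as the target (on this read-out lower numbers stand for an effect already at smaller amounts and higher numbers for an effect only at larger amounts of compound), compound 3 `Cc1ccc(N/N=C2\CCC(C)n3c2ncc(C(=O)O)c3=O)cc1` gives 280 nM, the lowest of three numbers, compared with compound 1 `CCOc1ccc(N/N=C2\CCC(C)n3c2ncc(C(=O)O)c3=O)cc1` at 17600 nM and compound 2 `Cc1cccc(N/N=C2\CCC(C)n3c2ncc(C(=O)O)c3=O)c1` at 72900 nM. Compound 4 `CC(C)c1ccc(N/N=C2\CCC(C)n3c2ncc(C(=O)O)c3=O)cc1` has isopropyl in place of methyl on an aromatic carbon, para to a large group (isopropyl in place of methyl on an aromatic carbon). Among the compounds with values here, two measured steps bear on this change. Both were large: a 260-fold lower number from compound 2 to compound 3 (2.42 log units; beyond the scatter) with 4-methylphenyl in place of 3-methylphenyl, and a 63-fold lower number from compound 1 to compound 3 (1.80 log units; beyond the scatter) with methyl in place of ethoxy. Going by these compounds, the second is the nearer precedent, although isopropyl itself is untested. A moderate rise is therefore expected, smaller than that second step, and the estimated change is a 6.4-fold higher number from compound 3 to compound 4 (0.81 log units; beyond the scatter). The estimate for compound 4 is 1800 nM, within 250 nM to 13000 nM.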

Compound 4, half-maximal effective concentration: 1200 nM
For compound 4 the middle estimate is 1.5-fold (0.18 log units) above the measured one; the measured number falls inside the stated range.
By their numbers in this assay, from the lowest: compound 3; then compound 4; then compound 1; then compound 2.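

In this assay the larger isopropyl group on this aromatic carbon, para to a large group, brings only a 4.3-fold higher number from compound 3 to compound 4 (0.63 log units; beyond the scatter) and so leaves methyl with the lowest number. Set against ethoxy at the same place, isopropyl gives a 15-fold lower number from compound 1 to compound 4 (1.17 log units; beyond the scatter) and thus stands much closer to methyl than ethoxy does. No available evidence explains this order.

The compounds shown leave open whether a longer chain such as propyl, or an amine or a chlorine atom, on this carbon would fall nearer to methyl or to ethoxy.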